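This account rests on a few compounds, and the source may have more. Where it says the series, first, only, none or still open, it means among the compounds named here.

Compound 1 `Cc1cc(S(N)(=O)=O)ccc1NC(=O)COc1ccc(Cl)cc1Oc1ccc2ccccc2c1Cl`: 40700 nM
Compound 2 `Cc1cc(S(N)(=O)=O)ccc1NC(=O)COc1ccc(F)cc1Oc1ccc2ccccc2c1Cl`: 47100 nM
Compound 3 `Cc1cc(S(N)(=O)=O)ccc1NC(=O)COc1ccc(F)cc1Oc1ccc2cc(Br)ccc2c1Cl`: 195000 nM

In an ADME assay on C8166 cells (Homo sapiens) for cytotoxicity, read by MTT assay (a lower number here means that less compound is tolerated, a higher number that more compound is tolerated), compound 1 gives the lowest of the three numbers. Its nearest neighbour is compound 2, and a 1.2-fold higher number from compound 1 to compound 2 (0.06 log units; within the scatter), so these two are not separated. The gap from compound 1 to compound 3 lies beyond the scatter. Compound 4 `Cc1cc(S(N)(=O)=O)ccc1NC(=O)COc1ccc(Cl)cc1Oc1c(C)cc2ccccc2c1Cl` differs from compound 1 by methyl in place of hydrogen on an aromatic carbon. Within the data shown here, no measured step adds a methyl group. Among the measured compounds shown here, the only step that adds a substituent to the same fused ring is a 4.1-fold higher number from compound 2 to compound 3 (0.62 log units; beyond the scatter), a modest rise. A methyl group is not a bromo group, so only a small rise, if any, is expected in this assay, and the step of a 1.4-fold higher number from compound 1 to compound 4 (0.13 log units; within the scatter) is the estimate. Compound 4 is therefore expected to give 55000 nM, within 25000 nM to 120000 nM.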

Compound 4, half-maximal cytotoxic concentration: 42600 nM
Beside the measured number, compound 4's estimate is 1.3-fold (0.11 log units) above it; low and high end bracket the measured number.
By their numbers in this assay, from the lowest: compounds 1, 4 and 2 (each within the scatter of the next); then compound 3.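

In this assay, methyl in place of hydrogen on this aromatic carbon gives no separable change (a 1.0-fold higher number from compound 1 to compound 4 (0.02 log units; within the scatter)). Among these compounds, none of the earlier compounds carried a substituent at this position, ortho to a large group, and here a methyl group leaves the number within the scatter. Nothing measured here speaks to the reason for this result.

As far as these compounds go, whether an amine, a carboxylic acid or a longer chain on this carbon would leave the number as close remains open. So does whether methyl gives the same result on compound 2, which carries fluoro in place of chloro.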